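The source may hold more compounds than are shown below. What is called first, only, known or untested is meant among the compounds shown, and "the series" means these compounds.

The compounds measured so far:

compound 1, `Oc1ccccc1CNc1ccc(-c2ccc(Cl)cc2)cc1`, 2390 nM
compound 2, `Oc1ccccc1CNc1ccc(-c2ccc(OC(F)(F)F)cc2)cc1`, "not active" (no number reported)
compound 3, `CC(=O)c1ccc(-c2ccc(NCc3ccccc3O)cc2)cc1`, "not active" (no number reported)

In a functional assay on Jurkat cells (Homo sapiens) for activation, with a stated time of 24 h (on this read-out lower numbers stand for an effect already at smaller amounts and higher numbers for an effect only at larger amounts of compound), compound 3 is reported as "not active" (no number reported), so no number stands for it. The same is true of compound 2, whose result in this assay is "not active" (no number reported). Only compound 1 has a number in this assay, namely 2390 nM; the two values of compound 1 and compound 3 show a numbered result beside an unnumbered one, and nothing more can be read from that pair.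

Compound 4, `CCCc1ccc(-c2ccc(NCc3ccccc3O)cc2)cc1`, differs from compound 3 in one place: propyl in place of acetyl on an aromatic carbon. Among the compounds with values here, since compound 3 is without a number, no measured step is available to gauge this change. The account expects the change to move compound 4 in the direction of an effect at smaller amounts than compound 3, though only to a modest extent, and with a real chance that the result is again an unnumbered one. In this assay compound 4 is estimated at 6000 nM, with a range from 1500 nM to 30000 nM.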

Compound 4, half-maximal effective concentration: 2390 nM
Compound 4: middle estimate off by 2.5-fold (0.40 log units), on the high side; the range from low to high includes it.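

In this assay the exchange of chloro for propyl on the aromatic carbon gives no change at the digits printed from compound 1 to compound 4 (within the scatter) and so the position para to a large group holds a numbered result with more than one kind of group. Until now compound 1 alone had a number, and compound 4 adds an all-carbon group to its halogen, while acetyl in compound 3 and trifluoromethoxy in compound 2 remain reported as "not active" at the same place. Nothing measured here explains why propyl and chloro give a number while acetyl and trifluoromethoxy do not.

On these data alone, it remains open whether a longer chain such as butyl, a smaller group such as methyl, or an amine or a carboxylic acid at this place would give a number. The compounds shown also leave open whether any change to the shared core would move the result away from that of compound 1 and compound 4.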